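Exchanging the aryl group on the shared core

A few compounds are considered here, and "the series" means these few. Any claim that something is new, unique, unknown or untested is made for them only; others in the source may bear on it.

In an ADME assay on MDBK cells (Bos taurus) for cytotoxicity, read by MTT assay, with a stated time of 96 h (a lower number here means that less compound is tolerated, a higher number that more compound is tolerated), compound 1 `COc1ccc(-c2nc3cc(/C(C)=N/NC(N)=O)ccc3n2C2CCCCC2)cc1` gives 54000 nM. For the measured compounds named here, compound 2 `COc1ccc(-c2nc3cc(/C(C)=N/NC(N)=O)ccc3n2C2CCCCC2)c(OC)c1` gives 36000 nM, so the two numbers lie within the scatter of each other and compound 2 stands level with its only neighbour. Compound 3 `C/C(=N\NC(N)=O)c1ccc2c(c1)nc(-c1ccccn1)n2C1CCCCC1` carries pyridin-2-yl in place of 2,4-dimethoxyphenyl on an aromatic carbon. Going by the values given here, one measured step bears on this change, and only loosely: a 1.5-fold lower number from compound 1 to compound 2 (0.18 log units; within the scatter), for methoxy in place of hydrogen on an aromatic carbon. No exchange of the whole aromatic ring has been measured in this series, so the expectation rests on that single small step and on the two values. No shift beyond the scatter is anticipated, and the expected move is a 1.4-fold higher number from compound 2 to compound 3 (0.14 log units; within the scatter). For compound 3 the estimated value in this assay is 50000 nM, with a range of 20000 nM to 100000 nM.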

Compound 3, half-maximal cytotoxic concentration: > 100000 nM
Compound 3 ended at the assay's limit; the forecaster's own chance of this, stated with the estimate: 25%; middle value at least 2.0-fold (0.30 log units) away from the limit.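

For the compounds shown here, at the aromatic carbon between two ring nitrogen atoms, exchanging the whole aryl group moves the reading in this assay: pyridin-2-yl in place of 2,4-dimethoxyphenyl gives an at least 2.7-fold higher number from compound 2 to compound 3 (0.44 log units; beyond the scatter), the only step printed as beyond the scatter. Pyridin-2-yl in place of 4-methoxyphenyl gives an at least 1.8-fold higher number from compound 1 to compound 3 (0.26 log units; that floor lies within the scatter), so the comparison with compound 1 does not by itself establish a shift. The reading for compound 3 is a limit of the assay and not a number: the limit of > 100000 nM in this assay, at which 1 of the 3 values shown sits.

Still open, going by these compounds, is whether the ring nitrogen of pyridin-2-yl or the absence of methoxy groups goes with the step, a question that unsubstituted phenyl at this position would address. Also open, on these data alone, is how an aryl ring carrying an amine or a carboxylic acid would read here.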